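Rat clearance notes: methyl to chloro on the core

This account rests on a few compounds, and the source may have more. Where it says the series, first, only, none or still open, it means among the compounds named here.

Two compounds of this series have been run in an in vivo ADME assay on the whole organism (strain Sprague-Dawley) for pharmacokinetics, with Rattus norvegicus as the target, at a dose of 1 mg/kg by the intravenous route; on this read-out higher numbers stand for fast clearance and lower numbers for slow clearance. Compound 1 `COc1cc(C2CCN(C(=O)C3CCN3)CC2)ccc1Nc1ncc2ccc(-c3ccccc3OC)n2n1` gives 32 mL/min/kg in this assay. Compound 2 `COc1cc(C2CCN(CC(N)=O)CC2)ccc1Nc1ncc2c(C)cc(-c3ccccc3N(C)S(C)(=O)=O)n2n1` is reported in this assay only as a limit, <= 4 mL/min/kg, and not as a number. Compound 2 therefore stands at the low end of the two numbers shown, while the number for compound 1 is the higher of the two; no single-site step connects these two compounds. Of the two values in this assay, one sits at the limit (the limit of <= 4 mL/min/kg in this assay, at which 1 of the 2 values shown sits).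

Compound 3 `COc1cc(C2CCN(CC(N)=O)CC2)ccc1Nc1ncc2c(Cl)cc(-c3ccccc3N(C)S(C)(=O)=O)n2n1` is not yet measured. It differs from compound 2 by chloro in place of methyl on an aromatic carbon. For the measured compounds named here, no measured step in this assay touches this position, so the direction is unknown from the data. The step in this assay is expected to be about an at least 1.2-fold higher number from compound 2 to compound 3 (0.09 log units; that floor lies within the scatter), not clearly beyond the scatter, with a fair chance that compound 3 is again reported only as a limit. Compound 3 is estimated at 5 mL/min/kg in this assay, with a range from 2 mL/min/kg to 12 mL/min/kg.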

Compound 3, clearance: <= 4 mL/min/kg
Compound 3: a limit, no number; the forecaster's own chance of this, stated with the estimate: 45%; middle value at least 1.2-fold (0.09 log units) from the limit.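

In this assay compound 3 is reported only as a limit, <= 4 mL/min/kg, and not as a number. With compound 2 also a limit, no step can be read between compound 2 and compound 3: the limit of <= 4 mL/min/kg in this assay, at which 2 of the 3 values shown sit.

The compounds shown leave open whether chloro in place of methyl on an aromatic carbon changes clearance at all.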